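Shortening the ester chain: compound 2 to compound 3

A few compounds are considered here, and "the series" means these few. Any claim that something is new, unique, unknown or untested is made for them only; others in the source may bear on it.

Compound 2 `O=C(OCCc1ccccc1)N(c1ccccc1)C1CN2CCC1CC2` gives 260 nM in an assay on CHO cells for displacement of a labelled ligand from muscarinic acetylcholine receptor M5 (Homo sapiens), read by scintillation counting, with a stated time of 2 h; a lower number here means a stronger inhibitor, a higher number a weaker inhibitor. For the measured compounds named here, of the two numbers known so far compound 2 stands highest; its nearest neighbour is compound 1 `COc1ccc(CCOC(=O)N(c2ccccc2)C2CN3CCC2CC3)cc1`, which in this assay gives 230 nM, and the step of a 1.1-fold higher number from compound 1 to compound 2 (0.05 log units; within the scatter) lies within the scatter, so nothing separates the two. That step is the only one measured, and it concerns the methoxy alone: hydrogen in place of methoxy on an aromatic carbon left the number essentially where it was.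

Compound 3 `COc1ccc(COC(=O)N(c2ccccc2)C2CN3CCC2CC3)cc1` differs from compound 2 by 4-methoxyphenyl in place of benzyl on a saturated chain carbon bound to an oxygen next to a carbonyl group. Cut one bond further out, the same difference reads phenethyl to 4-methoxybenzyl, so it combines the methoxy, which a 1.1-fold higher number from compound 1 to compound 2 (0.05 log units; within the scatter) showed to be without effect beyond the scatter, with one fewer chain carbon, for which no measured pair exists. Going by these compounds, the methoxy part is expected to contribute nothing; the shorter chain is untested, so the expected step of a 1.3-fold higher number from compound 2 to compound 3 (0.13 log units; within the scatter) in this assay is small, of uncertain direction, with a wider range than usual. Compound 3 is therefore expected to give 350 nM in this assay, within 110 nM to 1100 nM.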

Compound 3, inhibition constant: 470 nM
Compound 3: the middle estimate sits 1.3-fold (0.13 log units) below what was measured; measured number inside the range.
By their numbers in this assay, from the lowest: compounds 1, 2 and 3 (each within the scatter of the next, the first and the last beyond it).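

In this assay, for the compounds shown here, the pair that holds the methoxy constant gives the first reading of the chain alone: 4-methoxyphenyl in place of 4-methoxybenzyl on a saturated chain carbon bound to an oxygen next to a carbonyl group gives a 2.0-fold higher number from compound 1 to compound 3 (0.31 log units; beyond the scatter) as a modest step, just beyond the scatter. The step that also carries the methoxy difference, a 1.8-fold higher number from compound 2 to compound 3 (0.26 log units; within the scatter) in the same direction of the numbers, stays within the scatter, so the shorter chain is tolerated here and the binding number shifts only slightly across the three compounds. No supporting data bear on why the shorter chain behaves this way.

Still open, going by these compounds, is whether a longer chain such as phenylpropyl, or a plain phenyl on the shorter chain, would move the number beyond the scatter, and the methoxy result so far comes from the phenethyl chain alone. Equally open, on these data alone, is whether a group of another kind in place of methoxy, such as an amine or a carboxylic acid, would leave the number as unmoved as hydrogen did.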